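This account rests on a few compounds, and the source may have more. Where it says the series, first, only, none or still open, it means among the compounds named here.

Compound 1 `C#Cc1cn([C@@H]2O[C@H](CO)[C@@H](O)[C@H]2O)c2ncnc(C)c12` gives 19200 nM in a functional assay on A549 cells (Homo sapiens), read by MTT assay, with a stated time of 72 h; on this read-out lower numbers stand for stronger inhibition and higher numbers for weaker inhibition. Compound 2 `COc1nc(N)nc2c1c(-c1cccs1)cn2[C@@H]1O[C@H](CO)[C@@H](O)[C@H]1O` reaches only the limit of this assay, > 20000 nM. Compound 3 `Cc1ncnc2c1c(-c1cccs1)cn2[C@@H]1O[C@H](CO)[C@@H](O)[C@H]1O` likewise stops at the limit of this assay, > 20000 nM.

The difference between the cores of compound 2 and compound 3 is not broken down here. Compound 3 and compound 1 differ in one place, (ethynyl in place of thiophen-2-yl on an aromatic carbon), and that change gave an at least 1.0-fold lower number from compound 3 to compound 1 (0.01 log units; that floor lies within the scatter). Compound 4 `C#Cc1cn([C@@H]2O[C@H](CO)[C@@H](O)[C@H]2O)c2nc(N)nc(OC)c12` has not yet been measured in this assay. It stands to compound 2 as compound 1 stands to compound 3: the change is the same, (ethynyl in place of thiophen-2-yl on an aromatic carbon). Two of the three values sit at the limit of > 20000 nM in this assay, at which 2 of the 3 values shown sit, so the measured step from compound 3 to compound 1 rests on a limit and says little about the size of the effect. On that basis the step from compound 2 to compound 4 is expected to be a step that the limit leaves unreadable from compound 2 to compound 4 in this assay. Compound 4 is therefore estimated to give about 25000 nM, with a range from 12000 nM to 60000 nM, and a limit rather than a number is the likelier outcome.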

Compound 4, half-maximal inhibitory concentration: > 100000 nM
Compound 4 ended at the assay's limit (the forecaster's own chance of this, stated with the estimate: 65%); at least 4.0-fold (0.60 log units) between middle value and limit.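

Among the compounds shown here, compound 2 and compound 4 both stop at limits of this assay, so the step between them cannot be read and this result yields no new step. The compounds shown leave open whether ethynyl in place of thiophen-2-yl on an aromatic carbon changes the read-out on the core of compound 2, and by how much.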